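A few compounds are considered here, and "the series" means these few. Any claim that something is new, unique, unknown or untested is made for them only; others in the source may bear on it.

Measured compounds in an assay on isolated protein for displacement of a labelled ligand from metabotropic glutamate receptor 5 (Homo sapiens), with a stated time of 60 min, tested at 1 uM; on this read-out lower numbers stand for less inhibition and higher numbers for more inhibition at the one concentration tested (going by the name of the read-out):
compound 1 `Cc1ccc(S(=O)(=O)c2cnc3ccc(Cl)cc3c2N2CCC(C)CC2)cc1F` — 68%
compound 2 `COc1ccc2ncc(S(=O)(=O)c3ccc(C)c(F)c3)c(N3CCC(C)CC3)c2c1` — 73%
compound 3 `CC1CCN(c2c(S(=O)(=O)c3cccc(F)c3)cnc3ccc(F)cc23)CC1` — 76%

Compound 3 sits alongside the other two: compound 2 is nearest, compound 1 furthest, and neither gap reaches beyond the usual scatter, so the three numbers cannot be separated. For the measured compounds named here, the one single-point step in the set, a number 5 percentage points higher from compound 1 to compound 2 (within the scatter), concerns the substituent on the shared core and is also within the scatter.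

Compound 4 `Cc1ccc(S(=O)(=O)c2cnc3ccc(F)cc3c2N2CCC(C)CC2)cc1F` is not yet measured. It differs from compound 3 by methyl in place of hydrogen on an aromatic carbon. Going by the values given here, no measured step touches this change directly. Compounds 1 and 2 already carry the 3-fluoro-4-methylphenyl group and their values lie together with that of compound 3, which carries the 3-fluorophenyl group, but each of them differs from compound 3 in more than one place, so only the values themselves can be read. They give no sign of a shift tied to the methyl.

The expectation for compound 4 is therefore a step of a number 2 percentage points lower from compound 3 to compound 4 (within the scatter), nothing beyond the scatter. Compound 4 is estimated at 74% in this assay, in the range 60% to 88%.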

Compound 4, a percentage reported as inhibition, at one concentration (the size of the read-out at that concentration, not a potency): 86%
The estimate for compound 4 lay 12 percentage points below the measured number; measured number inside the range.
By their numbers in this assay, from the lowest: compounds 1, 2, 3 and 4 (each within the scatter of the next, the first and the last beyond it).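

In this assay the methyl on the aromatic carbon ortho to a fluoro group, para to a large group, gives a number 10 percentage points higher from compound 3 to compound 4 (within the scatter) and so cannot be separated from the 3-fluorophenyl parent; this position accepts the methyl without a step that can be read as a change. For the compounds shown here, with the 3-fluoro-4-methylphenyl group held constant, the substituent on the shared core now gives the first steps beyond the scatter: fluoro in place of methoxy gives a number 13 percentage points higher from compound 2 to compound 4 (beyond the scatter) and fluoro in place of chloro gives a number 18 percentage points higher from compound 1 to compound 4 (beyond the scatter) as modest steps, whereas methoxy in place of chloro gives a number 5 percentage points higher from compound 1 to compound 2 (within the scatter) and stays within it. No supporting data are available to explain these steps.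

The compounds shown leave open how ethyl, trifluoromethyl or a carboxylic acid would read on the aromatic carbon that carries the methyl, and whether the fluoro steps on the shared core would hold with the 3-fluorophenyl group. Going by these compounds alone, all four values are percentages at a single concentration, so they give no potency for any compound.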